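Methyl on the shared core of compound 2

The source may report more compounds than this note shows. Statements on the series, on what has been measured and on what is new or still open speak of the compounds shown alone.

Compound 2 `CC/C=C\C(=O)Nc1cc(Nc2nccc(-c3cn(C)c4ccc(F)cc34)n2)c(OC)cc1N(C)CCN(C)C` stands lowest of the three numbers in a functional assay on NCI-H1975 cells (Homo sapiens) for antiproliferative activity, read by MTT assay, with a stated time of 72 h (on this read-out higher numbers stand for weaker inhibition and lower numbers for stronger inhibition), where compound 2 gives 2600 nM. Compound 1 `CC/C=C\C(=O)Nc1cc(Nc2nccc(-c3cn(C)c4ccccc34)n2)c(OC)cc1N(C)CCN(C)C` gives 3860 nM in this assay, and the step of a 1.5-fold lower number from compound 1 to compound 2 (0.17 log units; within the scatter) is within the scatter. Compound 3 `COc1cc(N(C)CCN(C)C)c(NC(=O)/C=C\C(C)C)cc1Nc1nccc(-c2cn(C)c3ccc(F)cc23)n1` gives 7360 nM in this assay, and the step of a 2.8-fold higher number from compound 2 to compound 3 (0.45 log units; beyond the scatter) is beyond it.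

Compound 4 `CC/C=C\C(=O)Nc1cc(Nc2nc(C)cc(-c3cn(C)c4ccc(F)cc34)n2)c(OC)cc1N(C)CCN(C)C` differs from compound 2 by methyl in place of hydrogen on an aromatic carbon. Neither measured step touches this carbon of the shared core. The step of a 1.5-fold lower number from compound 1 to compound 2 (0.17 log units; within the scatter) is the closest analogy, a single heavy atom entering on an aromatic carbon, and it stays within the scatter. The step of a 2.8-fold higher number from compound 2 to compound 3 (0.45 log units; beyond the scatter) also adds methyl, but on a saturated chain carbon, and its modest size cannot be carried over to an aromatic position. For compound 4 a step within the scatter is expected, with no direction favoured. The step of a 1.3-fold higher number from compound 2 to compound 4 (0.13 log units; within the scatter) is the expected outcome. For compound 4 the estimate in this assay is 3500 nM, with a range from 1500 nM to 8000 nM.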

Compound 4, half-maximal inhibitory concentration: 10400 nM
Compound 4: the middle estimate sits 3.0-fold (0.47 log units) below what was measured; measured number above the stated range.
By their numbers in this assay, from the lowest: compounds 2, 1, 3 and 4 (each within the scatter of the next, the first and the last beyond it).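

On the shared core, this aromatic carbon next to the ring nitrogen does not tolerate every change: in this assay, methyl in place of hydrogen weakens inhibition (a 4.0-fold higher number from compound 2 to compound 4 (0.60 log units; beyond the scatter)). The other change on an aromatic carbon, fluoro in place of hydrogen (a 1.5-fold lower number from compound 1 to compound 2 (0.17 log units; within the scatter)), stays within the scatter, so a single heavy atom entering on an aromatic carbon does not give the same result at both places. Both methyl additions to compound 2 now raise the number, the other being on a saturated chain carbon (a 2.8-fold higher number from compound 2 to compound 3 (0.45 log units; beyond the scatter)), though two cases set no rule.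

No measurement shown bears on the reason for the weaker inhibition at this carbon. Whether any group is tolerated here stays open, since methyl is the only replacement for hydrogen shown; fluoro, an amine or a carboxylic acid at this carbon would test that.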